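Amide variation on two cores in a platelet series

The source may report more compounds than this note shows. Statements on the series, on what has been measured and on what is new or still open speak of the compounds shown alone.

Measured so far:
compound 1 `COc1ccc(-n2nc(C(=O)N3CCCCC3)cc2-c2ccc(Cl)cc2)cc1`: 7.9 nM
compound 2 `COc1ccc(-n2nc(C(=O)N3CCOCC3)cc2-c2ccc(Cl)cc2)cc1`: 7.3 nM
compound 3 `COc1ccc(-c2onc(C(=O)N3CCCCC3)c2-c2ccc(Cl)cc2)cc1`: 5030 nM

In a functional assay on a cell-free system (Platelet, plasma, Homo sapiens) for inhibition, read by turbidimetry, with a stated time of 3 min (a lower number here means a stronger inhibitor, a higher number a weaker inhibitor), compound 1 gives 7.9 nM and compound 2 gives 7.3 nM. The change from compound 1 to compound 2 is morpholin-4-yl in place of piperidin-1-yl on a carbonyl carbon, and the step is a 1.1-fold lower number from compound 1 to compound 2 (0.03 log units; within the scatter). Compound 3 carries a different core; how it differs from compound 1 is not broken down here, but in this assay compound 3 gives 5030 nM, far beyond the scatter from both.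

Compound 4 `COc1ccc(-c2onc(C(=O)N3CCOCC3)c2-c2ccc(Cl)cc2)cc1` is not yet measured. It differs from compound 3 by morpholin-4-yl in place of piperidin-1-yl on a carbonyl carbon, the same change as from compound 1 to compound 2. Because a 1.1-fold lower number from compound 1 to compound 2 (0.03 log units; within the scatter) was within the scatter, a similar step is expected here, a 1.1-fold lower number from compound 3 to compound 4 (0.04 log units; within the scatter), on the weaker core. Compound 4 is therefore estimated at 4600 nM in this assay, within 1500 nM to 15000 nM.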

Compound 4, half-maximal inhibitory concentration: 18400 nM
The estimate for compound 4 lay 4.0-fold (0.60 log units) below the measured number, outside the stated range (above it).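

Morpholin-4-yl in place of piperidin-1-yl on a carbonyl carbon gives a 3.7-fold higher number from compound 3 to compound 4 (0.56 log units; beyond the scatter) in this assay on the weaker core, so a flat result for this change on one core does not predict a flat result on the other. The comparison rests on a single pair per core and shows neither why the two cores respond differently nor how the change would behave on any further core. The two steps do not match: the same change on two cores in this assay, a 1.1-fold lower number (0.03 log units; within the scatter) from compound 1 to compound 2 and a 3.7-fold higher number (0.56 log units; beyond the scatter) from compound 3 to compound 4, 4.0-fold (0.60 log units) apart, beyond the scatter of two such steps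

The compounds shown leave open whether other amides, such as the pyrrolidin-1-yl or piperazin-1-yl amide, would also respond differently on the two cores. Also open, going by these compounds, is whether a secondary amide, which carries an amide hydrogen, would follow either pair.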